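The source may hold more compounds than are shown below. What is called first, only, known or untested is meant among the compounds shown, and "the series" means these compounds.

Three compounds share one core and differ only in the aryl group carried on an aromatic nitrogen. Compound 1 `Cc1ccc(-n2cc(COc3cccc(NC(=O)Nc4ccc(Cl)c(C(F)(F)F)c4)c3)nn2)cc1` gives 5430 nM in a functional assay on HepG2 cells (Homo sapiens) for inhibition, read by MTT assay, with a stated time of 72 h (on this read-out lower numbers stand for stronger inhibition and higher numbers for weaker inhibition), compound 2 `CCc1ccccc1-n1cc(COc2cccc(NC(=O)Nc3ccc(Cl)c(C(F)(F)F)c3)c2)nn1` gives 3530 nM, and compound 3 `CCc1cccc(-n2cc(COc3cccc(NC(=O)Nc4ccc(Cl)c(C(F)(F)F)c4)c3)nn2)c1` gives 37900 nM. Compound 3 stands at the highest number of the three, with steps a 7.0-fold higher number from compound 1 to compound 3 (0.84 log units; beyond the scatter) and an 11-fold higher number from compound 2 to compound 3 (1.03 log units; beyond the scatter) both beyond the scatter, so it is the least potent compound measured. Compound 4 `O=C(Nc1cccc(OCc2cn(-c3ccc(F)cc3)nn2)c1)Nc1ccc(Cl)c(C(F)(F)F)c1` has not yet been tested. The change is 4-fluorophenyl in place of 3-ethylphenyl on an aromatic nitrogen. The two steps that bear on it run the other way: going from a 4-methylphenyl or a 2-ethylphenyl group to 3-ethylphenyl cost a modest to large amount, so returning to a 4-substituted phenyl like that of compound 1 is expected to recover most of that loss. Compound 4 is therefore expected to show a clearly lower number, a step of about a 6.3-fold lower number from compound 3 to compound 4 (0.80 log units; beyond the scatter), because compound 1 with its 4-methylphenyl gave 5430 nM. The estimate for compound 4 is 6000 nM, within a range from 2500 nM to 15000 nM.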

Compound 4, half-maximal inhibitory concentration: 1350 nM
The estimate for compound 4 lay 4.4-fold (0.65 log units) above the measured number, outside the stated range (below it).
By their numbers in this assay, from the lowest: compound 4; then compounds 2 and 1 (each within the scatter of the next); then compound 3.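

In this assay, the position on the aromatic nitrogen proves able to give more than compounds 1 and 2 had shown, with a 2.6-fold lower number from compound 2 to compound 4 (0.42 log units; beyond the scatter) and a 28-fold lower number from compound 3 to compound 4 (1.45 log units; beyond the scatter), which makes compound 4 the most potent of the four. The clearest comparison is the change of a single group on the phenyl ring, fluoro in place of methyl on an aromatic carbon, which gives a 4.0-fold lower number from compound 1 to compound 4 (0.60 log units; beyond the scatter) and shows that this one replacement alone moves the number beyond the scatter. Nothing given here explains this gain.

The compounds shown leave open whether the gain is particular to fluoro, which an unsubstituted phenyl, 4-chlorophenyl or 4-methoxyphenyl group would test. They also leave open whether fluoro keeps its effect when moved, as in 3-fluorophenyl or 2-fluorophenyl.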